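Swapping 4-aminophenyl for pyridin-3-yl on the shared core

The source may hold more compounds than are shown below. What is called first, only, known or untested is meant among the compounds shown, and "the series" means these compounds.

Measured in a functional assay on MIA PaCa-2 cells (Homo sapiens) for cytotoxicity, read by MTT assay, with a stated time of 72 h; on this read-out lower numbers stand for stronger inhibition and higher numbers for weaker inhibition:
Compound 1 `COC1=CC(=O)c2c(COc3ccc([N+](=O)[O-])cc3)c(C)n(C)c2C1=O` gives 355 nM
Compound 2 `COC1=CC(=O)c2c(COc3ccc(N)cc3)c(C)n(C)c2C1=O` gives 160 nM
Compound 3 `COC1=CC(=O)c2c(COc3c(F)cc(F)cc3F)c(C)n(C)c2C1=O` gives 212 nM

Compound 2 stands at the low end of these numbers, within the scatter of compound 3. The next compound, compound 4 `COC1=CC(=O)c2c(COc3cccnc3)c(C)n(C)c2C1=O`, differs from it as follows: pyridin-3-yl in place of 4-aminophenyl on an oxygen on a saturated carbon. Going by the values given here, only one measured step bears on this group, the modest 2.2-fold lower number from compound 1 to compound 2 (0.35 log units; beyond the scatter), where amino replaced nitro on an aromatic carbon. Compound 4 no longer carries that amino group, so a step of similar modest size towards a higher number is expected in this assay. The expected change is a 1.7-fold higher number from compound 2 to compound 4 (0.23 log units; within the scatter). For compound 4 the estimated value is 270 nM, with an expected range of 110 nM to 650 nM.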

Compound 4, half-maximal inhibitory concentration: 1820 nM
Beside the measured number, compound 4's estimate is 6.7-fold (0.83 log units) below it; measured number outside the range, above it.
By their numbers in this assay, from the lowest: compounds 2, 3 and 1 (each within the scatter of the next, the first and the last beyond it); then compound 4.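

Going by these compounds alone, the step of an 11-fold higher number from compound 2 to compound 4 (1.06 log units; beyond the scatter) in this assay is large, well beyond a 2.2-fold lower number from compound 1 to compound 2 (0.35 log units; beyond the scatter), so at this position replacing the aromatic ring itself counts for more than the one substituent exchange seen earlier. Compound 4, the only one here with a hetero atom in that ring, gives the highest number of the four. Nothing available accounts for this step.

Compound 4 loses the amino group and gains a ring nitrogen in one change, and the compounds shown do not separate the two. On these data alone, how plain phenyl or pyridin-4-yl on the same oxygen would read remains open.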